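The source may hold more compounds than are shown below. What is called first, only, known or untested is meant among the compounds shown, and "the series" means these compounds.

In an ADME assay on the whole organism (strain CD-1) for pharmacokinetics, with Mus musculus as the target, at a dose of 3 mg/kg by the intravenous route (on this read-out lower numbers stand for slow clearance and higher numbers for fast clearance), compound 1 `CC(CCCCOc1ccccc1CN(C)C(=O)c1ccc(-c2ccco2)cc1)C(=O)O` gives 3 mL/min/kg, and compound 2 `CN(Cc1ccccc1OCCC[C@@H]1C[C@@H]1C(=O)O)C(=O)c1ccc(-c2ccco2)cc1` gives 1.7 mL/min/kg. For the measured compounds named here, these are the only two numbers so far, and they cannot be told apart: the one measured step is a 1.8-fold lower number from compound 1 to compound 2 (0.25 log units; within the scatter). In that step, 2-carboxycyclopropyl takes the place of 2-carboxypropyl on a saturated chain carbon, three bonds along the chain from an oxygen on an aromatic ring.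

The next compound is compound 3 `CN(Cc1ccccc1OCCC[C@@H]1C[C@H]1C(=O)O)C(=O)c1ccc(-c2ccco2)cc1`, and its relation to compound 2 is the two compounds have the same atoms and bonds and differ only in configuration as drawn: 1 of 2 stereo elements differ; a stereocentre at a saturated ring carbon is drawn S in compound 2 and R in compound 3. The two have the same atoms and bonds: a stereocentre at a saturated ring carbon is drawn S in compound 2 and R in compound 3. Going by the values given here, no measured pair differs only in this way, so the data give no direct guide. The nearest evidence is that one small step at the same end of the molecule, a 1.8-fold lower number from compound 1 to compound 2 (0.25 log units; within the scatter). On that basis, no change beyond the scatter is expected in this assay, and no direction can be favoured. The estimated change is a 1.3-fold higher number from compound 2 to compound 3 (0.11 log units; within the scatter). Compound 3 is expected at 2.2 mL/min/kg, within an estimated range of 0.9 mL/min/kg to 6 mL/min/kg.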

Compound 3, clearance: 0.6 mL/min/kg
The estimate for compound 3 lay 3.7-fold (0.56 log units) above the measured number, and the stated range ends above it.
By their numbers in this assay, from the lowest: compound 3; then compounds 2 and 1 (each within the scatter of the next).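

In this assay, inverting a single stereocentre at a saturated ring carbon gives a 2.8-fold lower number from compound 2 to compound 3 (0.45 log units; beyond the scatter), so at this position the three-dimensional arrangement of the ring matters for this read-out, and not only the presence of the ring. The replacement of 2-carboxypropyl by 2-carboxycyclopropyl now also gives a step beyond the scatter, a 5.0-fold lower number from compound 1 to compound 3 (0.70 log units; beyond the scatter), while the same replacement with the other drawn configuration gave a 1.8-fold lower number from compound 1 to compound 2 (0.25 log units; within the scatter), so the outcome of this replacement depends on the configuration that comes with it. The shift between the two cyclopropyl compounds can be assigned to that one stereocentre, because nothing else separates them: the fact that compounds 2 and 3 differ only in the configuration as drawn.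

The compounds shown leave open what the second stereocentre on the ring contributes, since it is drawn the same way in compound 2 and compound 3, and whether the configuration would still matter with a longer chain between the ring and the ether oxygen. They also leave open whether the same difference would persist if a tetrazole took the place of the carboxylic acid.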